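Compound 3: An Untested Change at the Ring Nitrogen Arm

The source may hold more compounds than are shown below. What is called first, only, known or untested is meant among the compounds shown, and "the series" means these compounds.

Measured compounds:
compound 1, `COc1ncc(-c2ccc3c(c2)N(Cc2ccc(F)cc2)C(=O)CO3)cc1NS(=O)(=O)c1ccc(F)cc1F`, 7840 nM
compound 2, `COc1ncc(-c2ccc3c(c2)N(Cc2ccncc2)C(=O)CO3)cc1NS(=O)(=O)c1ccc(F)cc1F`, 6960 nM

Both compounds were tested in a functional assay on SNU-638 cells (Homo sapiens) for antiproliferative activity, read by sulforhodamine B assay, with a stated time of 72 h; on this read-out lower numbers stand for stronger inhibition and higher numbers for weaker inhibition. Compound 2 has the lowest of the two numbers shown, but the step of a 1.1-fold lower number from compound 1 to compound 2 (0.05 log units; within the scatter) lies within the scatter, so the two cannot be told apart on this read-out.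

Compound 3, `COc1ncc(-c2ccc3c(c2)N(CCCn2ccccc2=O)C(=O)CO3)cc1NS(=O)(=O)c1ccc(F)cc1F`, has not been measured. It differs from compound 2 by a group of 9 heavy atoms (7 carbon, 1 nitrogen, 1 oxygen; one six-membered aromatic ring with 1 hetero atom) in place of a group of 6 heavy atoms (5 carbon, 1 nitrogen; one six-membered aromatic ring with 1 hetero atom), on a saturated chain carbon bound to an amide-type nitrogen in a ring. For the measured compounds named here, the only step that bears on this position is the one from compound 1 to compound 2, which was within the scatter; no measured step covers a group of this kind, so the expectation rests on that single comparison. Compound 3 is therefore expected to give a number close to that of compound 2, a step of a 1.0-fold higher number from compound 2 to compound 3 (0.00 log units; within the scatter), with no direction beyond the scatter. The estimate for compound 3 in this assay is 7000 nM, with a range from 2300 nM to 21000 nM.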

Compound 3, half-maximal inhibitory concentration: 6760 nM
Compound 3: middle estimate off by 1.0-fold (0.02 log units), on the high side; low and high end bracket the measured number.
By their numbers in this assay, from the lowest: compounds 3, 2 and 1 (each within the scatter of the next).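

At this place, on a saturated chain carbon bound to an amide-type nitrogen in a ring, the group of 9 heavy atoms leaves the number in this assay within the scatter: replacing pyridin-4-yl gives a 1.0-fold lower number from compound 2 to compound 3 (0.01 log units; within the scatter) and replacing the 4-fluorophenyl arm gives a 1.2-fold lower number from compound 1 to compound 3 (0.06 log units; within the scatter) on the same read-out. The earlier pair covered only pyridin-4-yl and 4-fluorophenyl, whereas this change adds heavy atoms, 1 oxygen, 1 double bond outside aromatic rings and a second hydrogen-bond acceptor without separating compound 3 from compound 1 or compound 2. Nothing in the data explains why these three cannot be told apart.

Still open, going by these compounds, is whether a carboxylic acid or a primary amine at this place would move the number beyond the scatter. The compounds shown also leave open whether the same holds with a different shared core.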